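Swapping Bromine for Fluorine on a Thioether Benzamide

This account rests on a few compounds, and the source may have more. Where it says the series, first, only, none or still open, it means among the compounds named here.

Compound 1 `Nc1ccccc1NC(=O)c1ccc(CSc2ccc(Br)cc2)cc1` stands second highest of the three numbers measured in a functional assay on A-375 cells (Homo sapiens) for inhibition, read by CCK-8 assay, with a stated time of 72 h, tested at 8 uM (a higher number here means more inhibition of growth at the concentration tested, a lower number less inhibition of growth), where compound 1 gives 6.17%. Its nearest neighbour is compound 2 `Cc1cc(C)cc(SCc2ccc(/C=C/C(=O)Nc3ccccc3N)cc2)c1`, which gives 2.49%, within the scatter of compound 1; furthest is compound 3 `Nc1ccccc1NC(=O)/C=C/c1ccc(CSc2cccc3ccccc23)cc1`, which gives 36%, beyond the scatter. Among the compounds with values here, the one measured step, a number 33.5 percentage points higher from compound 2 to compound 3 (beyond the scatter), changes the group on the sulfur and does not bear on a halogen exchange. Compound 4 `Nc1ccccc1NC(=O)c1ccc(CSc2ccc(F)cc2)cc1` differs from compound 1 by fluoro in place of bromo on an aromatic carbon. Within the data shown here, no measured step informs on such a swap. For compound 4, therefore, no change beyond the scatter is expected in this assay, a step of a number 0.2 percentage points lower from compound 1 to compound 4 (within the scatter). Compound 4 is estimated at 6%, ranging from -6% to 18%.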

Compound 4, percent growth inhibition at one concentration: 54.3%
Estimate against measurement, compound 4: 48.3 percentage points below; the measured number lies above the stated range.
By their numbers in this assay, from the lowest: compounds 2 and 1 (each within the scatter of the next); then compound 3; then compound 4.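

In this assay, within the data shown here, the single exchange of fluoro in place of bromo on an aromatic carbon gives a number 48.1 percentage points higher from compound 1 to compound 4 (beyond the scatter) and so shows that this para position is sensitive to the identity of its halogen. The earlier step had shown a large change only on replacing a whole group on the sulfur. Nothing available explains this rise.

Going by these compounds, whether chloro, an amine or a methoxy group at this position would behave like fluoro or like bromo remains open. So does whether the same exchange would have a similar effect on the core of compound 3.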